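Adding a second chloro to the tightest binder so far

The source may report more compounds than this note shows. Statements on the series, on what has been measured and on what is new or still open speak of the compounds shown alone.

Compound 3 `Cc1sc2c(Cl)cccc2c1S(=O)(=O)Nc1ccc2nccc(N3CCNCC3)c2c1`: 2 nM
Compound 2 `Cc1c(S(=O)(=O)Nc2ccc3nccc(N4CCNCC4)c3c2)sc2c(Cl)cc(Cl)cc12`: 6.31 nM
Compound 1 `O=S(=O)(Nc1ccc2nccc(N3CCNCC3)c2c1)c1cc(Cl)cc(Cl)c1`: 25.1 nM

In an assay on isolated protein for binding affinity to 5-hydroxytryptamine receptor 6 (Homo sapiens) (a higher number here means a weaker inhibitor, a lower number a stronger inhibitor), compound 3 gives 2 nM, the lowest of the three numbers; compound 2 gives 6.31 nM, and compound 1 gives 25.1 nM, both beyond the scatter above compound 3. Compound 4 `Cc1sc2c(Cl)cc(Cl)cc2c1S(=O)(=O)Nc1ccc2nccc(N3CCNCC3)c2c1` is the next step from compound 3: chloro in place of hydrogen on an aromatic carbon. For the measured compounds named here, no single-point step between measured compounds is available to calibrate this change. Compound 2 carries a related fused bicyclic with two chloro groups and stays close to compound 3, so a small step is expected. For compound 4 the estimated step of a 1.8-fold higher number from compound 3 to compound 4 (0.24 log units; within the scatter) is expected to fall within the scatter or slightly weaker. Compound 4 is estimated at 3.5 nM, between 1.5 nM and 9 nM.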

Compound 4, inhibition constant: 2 nM
Estimate against measurement, compound 4: 1.8-fold (0.24 log units) above, and the stated range covers the measured number.
By their numbers in this assay, from the lowest: compounds 3 and 4 (each within the scatter of the next); then compound 2; then compound 1.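

In this assay, for the compounds shown here, placing chloro in place of hydrogen on an aromatic carbon, meta to a chloro group, gives no change at the digits printed from compound 3 to compound 4 (within the scatter) as the first reading of a change in one place. This position of the six-membered aromatic ring therefore accepts a chloro group alongside the existing chloro without any visible loss of binding. No measurement shown here accounts for this result.

On these data alone, it remains open whether a methoxy group, an amine or a carboxylic acid at this carbon would also leave binding unchanged. As far as these compounds go, whether the same replacement would read alike on other compounds also remains open.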